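The source may hold more compounds than are shown below. What is called first, only, known or untested is meant among the compounds shown, and "the series" means these compounds.

In a functional assay on HT-29 cells (Homo sapiens) for antiproliferative activity, read by MTT assay, with a stated time of 72 h (a higher number here means a weaker inhibitor of growth, a lower number a stronger inhibitor of growth), compound 1 (`Nc1cc(OCc2ccccc2)nc(SCc2ccccc2)n1`) gives 53900 nM, and compound 2 (`CC(=O)Nc1cc(=O)n(CC(C)C)c(SCc2ccccc2)n1`) gives 68400 nM, two values within the usual scatter of each other. Compound 3 (`Cc1ccc2nc(-c3ccc([N+](=O)[O-])cc3)cn2c1`) reads > 100000 nM, which is a limit of the assay and not a number. It therefore stands at the limit of > 100000 nM in this assay, at which 1 of the 3 values shown sits. Compound 4 (`Cc1ccc2nc(-c3ccc(N)cc3)cn2c1`) carries amino in place of nitro on an aromatic carbon, para to a large group: amino in place of nitro on an aromatic carbon. Within the data shown here, no measured pair here shows this change. With compound 3 at > 100000 nM, a limit, any measurable movement in this assay is expected towards stronger growth inhibition, and only a modest one. The expected step is an at least 1.6-fold lower number from compound 3 to compound 4 (0.22 log units; that floor lies within the scatter). For compound 4 the estimated value is 60000 nM, with an expected range of 15000 nM to 100000 nM.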

Compound 4, concentration for 50% growth inhibition: 82900 nM
Estimate against measurement, compound 4: 1.4-fold (0.14 log units) below, within the range that was stated.
By their numbers in this assay, from the lowest: compounds 1, 2 and 4 (each within the scatter of the next). At a limit, above all of these: compound 3.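

On an aromatic carbon, para to a large group, amino in place of nitro is the only single change shown in this assay, and it gives an at least 1.2-fold lower number from compound 3 to compound 4 (0.08 log units; that floor lies within the scatter) as its one reading. The value of compound 3 is a limit and not a number: the limit of > 100000 nM in this assay, at which 1 of the 4 values shown sits. Compound 4 does give a measurable number, but the floor of this step lies within the scatter, so it shows no firm gain in growth inhibition. As far as these compounds go, whether a hydroxyl or a methoxy group on this carbon would move the number remains open. So does how far amino truly stands from nitro here.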